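Compound 3: a bridged amine on the aromatic carbon

The source may report more compounds than this note shows. Statements on the series, on what has been measured and on what is new or still open speak of the compounds shown alone.

Measured in an ADME assay on microsomes from liver (Mus musculus) for metabolic stability, read by LC-MS, with a stated time of 10 min; a higher number here means that more of the compound is left, a lower number that less of the compound is left:
- compound 1 `CN(C[C@H]1Cc2c(cccc2N2CCN(C3CC3)CC2)CN1)[C@H]1CCCc2cccnc21` gives 7%
- compound 2 `C[C@@H]1CN(c2cccc3c2C[C@H](CN(C)[C@H]2CCCc4cccnc42)NC3)C[C@H](C)N1C` gives 39.6%

Compound 2, at 39.6% in this assay, is the higher of the two measured compounds. Compound 3 `CN(C[C@H]1Cc2c(cccc2N2C[C@@H]3C[C@H]2CN3)CN1)[C@H]1CCCc2cccnc21` keeps the shared core and changes only the group on the aromatic carbon, described here as a group of 7 heavy atoms (5 carbon, 2 nitrogen; 2 five-membered non-aromatic rings with 1 hetero atom each) in place of a group of 9 heavy atoms (7 carbon, 2 nitrogen; one six-membered non-aromatic ring with 2 hetero atoms), on an aromatic carbon and giving a bridged group with two five-membered rings. For the measured compounds named here, one measured step bears on this place: replacing 4-cyclopropylpiperazin-1-yl with 3,4,5-trimethylpiperazin-1-yl gave a number 32.6 percentage points higher from compound 1 to compound 2 (beyond the scatter) and shows that the group here can matter a great deal. That single step gives no direction for a group of a new shape, so the expected change is a number 5.4 percentage points higher from compound 2 to compound 3 (within the scatter) with no move beyond the scatter, though a large step either way remains possible. In this assay compound 3 is estimated at 45% (18% to 75%).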

Compound 3, percent of the compound remaining: 36.3%
Beside the measured number, compound 3's estimate is 8.7 percentage points above it; low and high end bracket the measured number.
By their numbers in this assay, from the lowest: compound 1; then compounds 3 and 2 (each within the scatter of the next).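

In this assay, changing the piperazine ring for the bridged group with two five-membered rings, which also carries 1 hydrogen-bond donor where the 3,4,5-trimethylpiperazin-1-yl group has none, leaves the result within the scatter: a number 3.3 percentage points lower from compound 2 to compound 3 (within the scatter). The second step, a number 29.3 percentage points higher from compound 1 to compound 3 (beyond the scatter), means that two groups of different shape now stand clear of the 4-cyclopropylpiperazin-1-yl group, so the higher numbers at this aromatic carbon do not depend on the trimethylpiperazine alone. Nothing available explains why these groups compare as they do.

As far as these compounds go, it remains open whether the cyclopropyl ring itself sets compound 1 apart, which a 4-methylpiperazin-1-yl group on the same carbon could help to test. A morpholin-4-yl group, with oxygen in place of one ring nitrogen, would show whether that second nitrogen matters here.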